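The compounds below may be only part of what the source reports. "The series", "measured", "known", "first", "only" and "open" are said of these compounds alone.

Measured so far:
Compound 1 `O=C(CCCCC(S)CCS)Nc1ccccc1`: 1.32%
Compound 2 `O=C(CCCCC(S)CCS)Nc1cccc(C(F)(F)F)c1`: 1.66%

Both compounds were tested in a functional assay on Bel-7402 cells (Homo sapiens) for inhibition, read by MTT assay, with a stated time of 24 h, tested at 1 ug/mL; on this read-out lower numbers stand for less inhibition of growth and higher numbers for more inhibition of growth at the one concentration tested. Compound 2, at 1.66%, cannot be told apart from compound 1, at 1.32%, since the two values lie within the scatter of each other. Both numbers show very little inhibition of growth at the single concentration tested.

The next compound, compound 3 `Cc1cccc(NC(=O)CCCCC(S)CCS)c1`, has methyl in place of trifluoromethyl on an aromatic carbon. Within the data shown here, one measured step bears on this position, a number 0.3 percentage points higher from compound 1 to compound 2 (within the scatter). That step put trifluoromethyl in place of hydrogen on an aromatic carbon, and it was small. Among the measured compounds shown here, no measured compound yet carries methyl, so this comparison is only indirect. Methyl replaces a group whose arrival left the value of compound 2 within the scatter of compound 1, so no change beyond the scatter is expected in this assay.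

The expected step is a number 0 percentage points higher from compound 2 to compound 3 (within the scatter), which is an estimate and stays within the scatter. For compound 3 the estimated value is 1.7%, with an expected range from 0% to 6%.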

Compound 3, percent growth inhibition at one concentration: 11.1%
Compound 3: middle estimate off by 9.4 percentage points, on the low side; the whole stated range lies below it.
By their numbers in this assay, from the lowest: compounds 1, 2 and 3 (each within the scatter of the next).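

Methyl, with its one heavy atom, brings a third group to this aromatic carbon, and the comparison now covers two further changes in this assay: methyl in place of trifluoromethyl (a number 9.4 percentage points higher from compound 2 to compound 3 (within the scatter)) and methyl in place of hydrogen (a number 9.8 percentage points higher from compound 1 to compound 3 (within the scatter)). Both steps are within the scatter, so hydrogen, trifluoromethyl and methyl cannot be told apart at this position, even though trifluoromethyl, with four heavy atoms, is the bulkiest of the three by that count, and compound 3 cannot be called better than either earlier compound. No measurement shown here offers an explanation for the value of compound 3.

Whether the value of compound 3 would hold up on repeat testing remains open, since a single concentration in one kind of cell gives only a narrow view of these compounds. Also open, going by these compounds, is whether a different group on this aromatic carbon, such as an amine, a carboxylic acid or a longer chain, would move the value beyond the scatter.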